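From allyloxy to carboxymethoxy on the shared core

This account rests on a few compounds, and the source may have more. Where it says the series, first, only, none or still open, it means among the compounds named here.

Compound 1 (`CCCCCCCC[C@@]1(C)SC(=O)C=C1OC`) gives 16.4 ug/mL
Compound 2 (`C=CCOC1=CC(=O)S[C@]1(C)CCCCCCCC`) gives 14.5 ug/mL

In a functional assay on MCF7 cells (Homo sapiens) for inhibition, read by radiometric assay and XTT assay (a higher number here means a weaker inhibitor, a lower number a stronger inhibitor), compound 2 stands at 14.5 ug/mL, level with compound 1 within the scatter. The compound still to be measured is compound 3 (`CCCCCCCC[C@@]1(C)SC(=O)C=C1OCC(=O)O`). It carries carboxy in place of vinyl on a saturated chain carbon bound to an oxygen on an unsaturated carbon. For the measured compounds named here, only one measured step bears on this place: a 1.1-fold lower number from compound 1 to compound 2 (0.05 log units; within the scatter). Going by the values given here, that step brought in vinyl, and no measured compound carries carboxy, so it sets no firm size for the new change. A shift toward a weaker inhibitor is expected, with wide uncertainty. The estimated step is a 1.9-fold higher number from compound 2 to compound 3 (0.29 log units; within the scatter). For compound 3 the expected value is 28 ug/mL, with an estimated range of 12 ug/mL to 70 ug/mL.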

Compound 3, half-maximal inhibitory concentration: 50.3 ug/mL
Beside the measured number, compound 3's estimate is 1.8-fold (0.25 log units) below it; measured number inside the range.
By their numbers in this assay, from the lowest: compounds 2 and 1 (each within the scatter of the next); then compound 3.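

In this assay, the place on a saturated chain carbon bound to an oxygen on an unsaturated carbon is not indifferent to its substituent: compound 1 and compound 2 read level, while carboxy gives a 3.5-fold higher number from compound 2 to compound 3 (0.54 log units; beyond the scatter) and a 3.1-fold higher number from compound 1 to compound 3 (0.49 log units; beyond the scatter). For the compounds shown here, both steps are modest but beyond the scatter, making this the first change to move the number, here toward a weaker inhibitor. Nothing at hand bears on what lies behind this shift.

Still open, as far as these compounds go, is whether the shift belongs to the free carboxy itself or would persist with a methyl ester, a primary amide or an amine at the same place. Also open, from the compounds shown here alone, is whether a longer chain carrying the carboxy would shift the number by a similar amount.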